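Moving the trifluoromethyl group within the phenyl ring

The compounds below may be only part of what the source reports. "The series", "measured", "known", "first", "only" and "open" are said of these compounds alone.

Compound 3 `Cc1cc(NC(=O)Cn2nnc(-c3ccc(C(F)(F)F)cc3)n2)n(C2CCCCC2)n1` gives 94% in an assay on HEK293 cells for activation of Kir3.1/Kir3.2 (Homo sapiens), read by thallium flux; on this read-out lower numbers stand for smaller maximal responses and higher numbers for larger maximal responses. Among the three measured compounds it stands second highest. Its nearest neighbour is compound 2 `Cc1cc(NC(=O)Cn2nnc(-c3ccnc(F)c3)n2)n(C2CCCCC2)n1`, which gives 95%, and a number 1 percentage points lower from compound 2 to compound 3 (within the scatter). The furthest is compound 1 `Cc1cc(NC(=O)Cn2nnc(-c3ccccc3F)n2)n(C2CCCCC2)n1`, which gives 88%, and a number 6 percentage points higher from compound 1 to compound 3 (within the scatter). Compound 4 `Cc1cc(NC(=O)Cn2nnc(-c3cccc(C(F)(F)F)c3)n2)n(C2CCCCC2)n1` is not yet measured. The change from compound 3 to compound 4 is 3-(trifluoromethyl)phenyl in place of 4-(trifluoromethyl)phenyl on an aromatic carbon.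

All three measured steps exchange the aromatic group on this same carbon: a number 7 percentage points higher from compound 1 to compound 2 (within the scatter), a number 6 percentage points higher from compound 1 to compound 3 (within the scatter) and a number 1 percentage points lower from compound 2 to compound 3 (within the scatter), each within the scatter. Among the compounds with values here, none of them moves the trifluoromethyl group within the phenyl ring, so there is no direct precedent for this change; the three aromatic groups tried so far all give maximal responses close to one another. On that basis no step beyond the scatter is expected in this assay for compound 4. The estimated step is a number 2 percentage points lower from compound 3 to compound 4 (within the scatter). Compound 4 is expected to give 92%, within a range of 80% to 102%.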

Compound 4, largest response reached (Emax), in percent of the reference or control that the assay uses: 86%
Compound 4: the middle estimate sits 6 percentage points above what was measured, and the stated range covers the measured number.
By their numbers in this assay, from the lowest: compounds 4, 1, 3 and 2 (each within the scatter of the next).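

The first direct test of where the trifluoromethyl group sits on the phenyl ring stays inside the scatter in this assay: a number 8 percentage points lower from compound 3 to compound 4 (within the scatter). The two other new steps, a number 9 percentage points lower from compound 2 to compound 4 (within the scatter) and a number 2 percentage points lower from compound 1 to compound 4 (within the scatter), do the same, so this read-out does not separate the four aromatic groups on this carbon, 3-(trifluoromethyl)phenyl and 4-(trifluoromethyl)phenyl included. No supporting measurement is available to explain the spread of these numbers.

Still open, going by these compounds, is whether this carbon keeps the same maximal response with a group of another kind, such as a primary amine, a carboxylic acid or a longer alkyl chain in place of the aromatic ring. Maximal response alone also leaves open how these aromatic groups compare in the concentration needed to reach it.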